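The source may hold more compounds than are shown below. What is called first, only, known or untested is meant among the compounds shown, and "the series" means these compounds.

Compound 3, with the structure `COc1cc(/C=C/C(=O)Nc2ccccc2)ccc1OCCCCCCN1CCCC1`, sits close to its two neighbours in a physicochemical assay for lipophilicity, using the shake flask method, measured as octanol-water partition, at pH 7.4; a higher number here means a more lipophilic compound, a lower number a more polar compound: compound 3 gives 1.76, compound 2, with the structure `COc1cc(/C=C/C(=O)Nc2ccccc2)ccc1OCCCCCCN1CCCCC1`, gives 1.77, and compound 1, with the structure `COc1cc(/C=C/C(=O)Nc2ccccc2)ccc1OCCCCCN(C)C`, gives 1.61. Compound 4, with the structure `COc1cc(/C=C/C(=O)Nc2ccccc2)ccc1OCCCCCCCCCCN1CCCCC1`, differs from compound 3 by 4-(piperidin-1-yl)butyl in place of pyrrolidin-1-yl on a saturated chain carbon, six bonds along the chain from an oxygen on an aromatic ring. Of the steps already measured, only the ring exchange is directly comparable: a number 0.01 log units lower from compound 2 to compound 3 (within the scatter). Within the data shown here, no measured step adds four chain carbons. Among the measured compounds shown here, the change brings in a group with nine carbons where four stood before, and no measured step covers it. A clear rise in this assay is expected for compound 4, estimated as a number 1.64 log units higher from compound 3 to compound 4 (beyond the scatter). For compound 4 the estimated value is 3.4, expected to fall between 2.7 and 4.1.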

Compound 4, partition coefficient: 1.83
Compound 4: middle estimate off by 1.57 log units, on the high side, and the stated range ends above it.
By their numbers in this assay, from the lowest: compounds 1, 3, 2 and 4 (each within the scatter of the next).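

In this assay, putting 4-(piperidin-1-yl)butyl, with 9 carbons, in place of pyrrolidin-1-yl, with 4, on this saturated chain carbon gives a number 0.07 log units higher from compound 3 to compound 4 (within the scatter). The comparisons with the other two compounds read the same way: a number 0.06 log units higher from compound 2 to compound 4 (within the scatter) and a number 0.22 log units higher from compound 1 to compound 4 (within the scatter). So across these four compounds, a much larger chain end leaves the number within the scatter, and nothing available speaks to why. From the compounds shown here alone, whether a morpholin-4-yl group or a carboxylic acid at the chain end would shift this number remains open. So does the effect of a still longer chain.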